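A few compounds are considered here, and "the series" means these few. Any claim that something is new, unique, unknown or untested is made for them only; others in the source may bear on it.

Compound 1 (`O=C(N[C@H](/C=C/S(=O)(=O)c1ccccc1)CCc1ccccc1)c1cccc2cccnc12`) gives > 80000 nM in an ADME assay on HepG2 cells (Homo sapiens) for cytotoxicity (on this read-out lower numbers stand for higher toxicity in this test and higher numbers for lower toxicity in this test), and this is a limit of the assay, not a number. Compound 2 (`CCCC[C@@H](/C=C/S(=O)(=O)c1ccccc1)NC(=O)c1cccc2cccnc12`) gives 36500 nM in this assay. Compound 3 (`O=C(NC/C=C/S(=O)(=O)c1ccccc1)c1cccc2cccnc12`) is still to be measured and differs from compound 1 by hydrogen in place of phenethyl on a saturated chain carbon bound to an amide-type nitrogen and a double-bonded chain carbon. Among the measured compounds shown here, only one measured step bears on this change. Compound 2 shortens the same side chain and sets the likely direction with an at least 2.1-fold lower number from compound 1 to compound 2 (0.34 log units; beyond the scatter), a step beyond the scatter. With a single step that starts from a limit, the size remains loose. The expected move is an at least 2.6-fold lower number from compound 1 to compound 3 (0.42 log units; beyond the scatter), toward a lower number. For compound 3 the estimated value is 30000 nM, with an expected range from 9000 nM to 80000 nM.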

Compound 3, half-maximal cytotoxic concentration: 55500 nM
Compound 3: middle estimate off by 1.9-fold (0.27 log units), on the low side; measured number inside the range.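

In this assay, hydrogen in place of butyl on the saturated chain carbon gives a 1.5-fold higher number from compound 2 to compound 3 (0.18 log units; within the scatter), so removing the butyl chain leaves no readable difference. The lower number seen on going from phenethyl to butyl does not continue on going from butyl to hydrogen. Hydrogen in place of phenethyl gives an at least 1.4-fold lower number from compound 1 to compound 3 (0.15 log units; that floor lies within the scatter), so this change, unlike the shortening to butyl, has no floor beyond the scatter. The value of compound 1 is a limit of the assay, and the true size of this step stays unknown because it starts from that limit: the limit of > 80000 nM in this assay, at which 1 of the 3 values shown sits.

Going by these compounds, whether phenethyl stands apart through its phenyl ring or through its chain length remains open, and a plain hexyl chain or a benzyl group on this carbon would separate the two. On these data alone, how an amine or a carboxylic acid at this place would read in this assay also remains open.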